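Methyl for hydrogen on a chain carbon, two settings

The source may hold more compounds than are shown below. What is called first, only, known or untested is meant among the compounds shown, and "the series" means these compounds.

The series rests on a shared core carrying a benzyloxy group, and the compounds differ only in the small substituent on a saturated chain carbon attached to that core. Compound 1 `CSCc1c(C)nc2c(OCc3ccccc3)cccn12` and compound 2 `CCSCc1c(C)nc2c(OCc3ccccc3)cccn12` carry a sulfur-bearing chain; compound 3 `Cc1nc2c(OCc3ccccc3)cccn2c1C` carries a methyl in its place. In a functional assay on the whole organism with Rattus norvegicus as the target, with a stated time of 4 h, at a dose of 40 mg/kg by the intraperitoneal route (a lower number here means less inhibition, a higher number more inhibition at the dose given (going by the name of the read-out)), compound 1 gives 29%, compound 2 gives 36% and compound 3 gives 99%.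

The change from compound 1 to compound 2 is methyl in place of hydrogen on a saturated chain carbon bound to a sulfur, and it produced a number 7 percentage points higher from compound 1 to compound 2 (within the scatter). The cores of compound 1 and compound 3 differ by hydrogen in place of methylsulfanyl on a saturated chain carbon bound to an aromatic carbon, a change that produced a number 70 percentage points higher from compound 1 to compound 3 (beyond the scatter); from compound 2 to compound 3 the step was a number 63 percentage points higher from compound 2 to compound 3 (beyond the scatter). Compound 3 stands highest of the three, and both of its steps lie beyond the scatter.

Compound 4 `CCc1nc2c(OCc3ccccc3)cccn2c1C` has not been measured. It differs from compound 3 by methyl in place of hydrogen on a saturated chain carbon bound to an aromatic carbon. This is the same kind of change as from compound 1 to compound 2, but not the same: there the saturated chain carbon is bound to a sulfur, here it is bound to an aromatic carbon. The earlier step was within the scatter, and compound 3 already sits near the top of the range, so the expected step from compound 3 to compound 4 is a number 7 percentage points lower from compound 3 to compound 4 (within the scatter), resting on compound 3 with 99%. Compound 4 is estimated at 92%, between 70% and 100%.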

Compound 4, a percentage reported as inhibition, in the whole organism at one dose (the size of the read-out at that dose, not a potency): 79%
Beside the measured number, compound 4's estimate is 13 percentage points above it; the measured number falls inside the stated range.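

In this assay, methyl in place of hydrogen on a saturated chain carbon bound to an aromatic carbon gave a number 20 percentage points lower from compound 3 to compound 4 (beyond the scatter), and this step does not match the one seen for the same kind of change on a chain carbon bound to a sulfur: the same change on two cores in this assay, a number 7 percentage points higher (within the scatter) from compound 1 to compound 2 and a number 20 percentage points lower (beyond the scatter) from compound 3 to compound 4, 27 percentage points apart, beyond the scatter of two such steps. In this series, then, the change does not carry from one core to the other as a step of one size, and what it does on the core of compound 1 says little about what it does on the core of compound 3. What the comparison does not show is why the two settings part, or whether the same gap would appear at another dose or time, as each setting rests on a single pair and the read-out gives the size of the inhibition at one dose rather than a potency.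

The compounds shown leave open whether a longer chain, such as propyl, on the same carbon would extend the fall seen from compound 3 to compound 4 or level off. They also leave open how an amine or a carboxylic acid at that place would read, and whether the benzyloxy group, constant throughout, shapes either step.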